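Halogen ring replaces dimethoxy ring on the amine nitrogen

The source may hold more compounds than are shown below. What is called first, only, known or untested is meant among the compounds shown, and "the series" means these compounds.

Three measured compounds share one core and differ only in the ring attached to an amine nitrogen. Compound 1 `Cc1ccc(S(=O)(=O)/N=C(/CCNC2=CC(=O)c3ccccc3C2=O)Nc2ccc(Cl)cc2)cc1` carries a 4-chlorophenyl there, and in a functional assay on HeLa cells (Homo sapiens) for cytotoxicity, read by MTT assay, with a stated time of 48 h (on this read-out higher numbers stand for weaker inhibition and lower numbers for stronger inhibition), compound 1 gives 13400 nM. Compound 2 `Cc1ccc(S(=O)(=O)/N=C(/CCNC2=CC(=O)c3ccccc3C2=O)Nc2ccccc2I)cc1` carries a 2-iodophenyl, and compound 2 gives 19100 nM. Compound 3 `COc1ccc(N/C(CCNC2=CC(=O)c3ccccc3C2=O)=N\S(=O)(=O)c2ccc(C)cc2)cc1OC` carries a 3,4-dimethoxyphenyl, and compound 3 gives 14500 nM. These three numbers sit close together, and compound 3 stands among its neighbours rather than apart from them.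

Compound 4 `Cc1ccc(S(=O)(=O)/N=C(/CCNC2=CC(=O)c3ccccc3C2=O)Nc2ccc(Cl)cc2Cl)cc1` has not yet been measured. The change from compound 3 to compound 4 is 2,4-dichlorophenyl in place of 3,4-dimethoxyphenyl on an amine nitrogen. For the measured compounds named here, two measured steps bear on this exchange, since each also swaps the ring on that same nitrogen: the step of a 1.1-fold higher number from compound 1 to compound 3 (0.03 log units; within the scatter) and the step of a 1.3-fold lower number from compound 2 to compound 3 (0.12 log units; within the scatter). Neither reached beyond the scatter, whether the departing or arriving ring carried a halogen or methoxy groups. The expected step is therefore a 1.0-fold lower number from compound 3 to compound 4 (0.02 log units; within the scatter), meaning no change beyond the scatter is anticipated in this assay. Compound 4 is estimated to give 14000 nM, with an expected range from 7000 nM to 28000 nM.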

Compound 4, half-maximal inhibitory concentration: 20500 nM
For compound 4 the middle estimate is 1.5-fold (0.17 log units) below the measured one, within the range that was stated.
By their numbers in this assay, from the lowest: compounds 1, 3, 2 and 4 (each within the scatter of the next).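

In this assay, this amine nitrogen now also carries a ring with two chlorines, and 2,4-dichlorophenyl in place of 3,4-dimethoxyphenyl gives a 1.4-fold higher number from compound 3 to compound 4 (0.15 log units; within the scatter), even though the departing ring counts 2 hydrogen-bond acceptors and the entering ring counts 0, while the same ring in place of 2-iodophenyl gives a 1.1-fold higher number from compound 2 to compound 4 (0.03 log units; within the scatter). The pair that differs by a single substituent adds a further test, since chloro in place of hydrogen on an aromatic carbon gives a 1.5-fold higher number from compound 1 to compound 4 (0.18 log units; within the scatter), so a second chlorine on this ring does not move the number beyond the scatter, and across these four substituted phenyl rings this position shows no preference in this assay. No measurement is available that would explain these numbers.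

All four rings are substituted phenyl groups, which leaves open whether the number would hold with a pyridine ring or a cyclohexyl group on this nitrogen, or with a phenyl ring bearing a carboxylic acid. Also open, as far as these compounds go, is whether a change elsewhere on the shared core, such as a longer chain leading to the other amine nitrogen, would move the number beyond the scatter.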